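Nitro in Place of Bromo: What to Expect for Compound 4

The source may report more compounds than this note shows. Statements on the series, on what has been measured and on what is new or still open speak of the compounds shown alone.

compound 1 `CCOC(=O)Cc1n[nH]c(N)n1`: 33.6%
compound 2 `CCOC(=O)Cc1nc(N)n(C(=O)c2ccccc2)n1`: 38.5%
compound 3 `CCOC(=O)Cc1nc(N)n(C(=O)c2ccc(Br)cc2)n1`: 43%

Of the compounds shown here, three have been tested in a functional assay on the whole organism (strain albino) for inhibition, with Rattus norvegicus as the target, read by paw edema, with stated times of 30 min and 2 h, at a dose of 5 mg/kg by the oral route; on this read-out lower numbers stand for less inhibition and higher numbers for more inhibition at the one dose given (going by the name of the read-out). Compound 3 carries the highest of the three numbers, but both compound 2 and compound 1 lie within the usual scatter of it, so no real order among them can be claimed. Among the measured compounds shown here, the only measured step, a number 4.5 percentage points higher from compound 2 to compound 3 (within the scatter), came from bromo entering in place of hydrogen on the aromatic carbon.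

Compound 4 `CCOC(=O)Cc1nc(N)n(C(=O)c2ccc([N+](=O)[O-])cc2)n1` differs from compound 3 as follows: nitro in place of bromo on an aromatic carbon. For the measured compounds named here, no measured step exchanges one group for another on that carbon, so the sole guide is that adding bromo there moved the number little. For compound 4 the expected step is therefore a number 1 percentage points lower from compound 3 to compound 4 (within the scatter), nothing beyond the scatter. Compound 4 is estimated at 42%, between 30% and 55%.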

Compound 4, a percentage reported as inhibition, in the whole organism at one dose (the size of the read-out at that dose, not a potency): 46.3%
For compound 4 the middle estimate is 4.3 percentage points below the measured one, and the stated range covers the measured number.
By their numbers in this assay, from the lowest: compounds 1, 2, 3 and 4 (each within the scatter of the next, the first and the last beyond it).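

In this assay, nitro in place of bromo gives a number 3.3 percentage points higher from compound 3 to compound 4 (within the scatter) and nitro in place of hydrogen gives a number 7.8 percentage points higher from compound 2 to compound 4 (within the scatter) on the same aromatic carbon. This position therefore accepts a group of three heavy atoms with two hydrogen-bond acceptors, as well as a single bromine, without any step leaving the scatter. No measurement here offers an explanation for these small steps. Still open, as far as these compounds go, is whether an amine or a carboxylic acid on this carbon would give a step beyond the scatter.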